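The source may report more compounds than this note shows. Statements on the series, on what has been measured and on what is new or still open speak of the compounds shown alone.

Compound 1 `COc1cc(NS(=O)(=O)c2ccc(C)cc2)c2nc(C)ccc2c1` is the weaker of the two compounds measured in an assay on OCI-Ly3 cells for activation of NF-kappa-B inhibitor alpha (Homo sapiens), read by a luciferase reporter (a lower number here means a smaller maximal response, a higher number a larger maximal response), where compound 1 gives 150%. Compound 2 `Cc1ccc2cccc(NS(=O)(=O)c3ccccc3N)c2n1` gives 250% in this assay, a larger maximal response that lies well beyond the usual scatter. Compound 3 `COc1cc(NS(=O)(=O)c2ccc(C)cc2N)c2nc(C)ccc2c1` is not yet measured and differs from compound 1 by amino in place of hydrogen on an aromatic carbon. Among the measured compounds shown here, no single-change step of this kind has been measured, so the expected size of the step rests on a loose hint: compound 2 also carries an amino group and gives 250%. A moderate rise in this assay is therefore expected from compound 1 to compound 3, a number 50 percentage points higher from compound 1 to compound 3 (beyond the scatter). For compound 3 the estimate is 200% with a range from 140% to 280%.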

Compound 3, largest response reached (reported as efficacy), in percent of the reference or control that the assay uses: 23%
Compound 3: middle estimate off by 177 percentage points, on the high side; measured number outside the range, below it.
By their numbers in this assay, from the lowest: compound 3; then compound 1; then compound 2.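

Changing 4-methylphenyl to 2-amino-4-methylphenyl adds only one heavy atom, yet it gives a number 127 percentage points lower from compound 1 to compound 3 (beyond the scatter) in this assay. This is the first single-change step shown, and it marks this aromatic carbon, ortho to a large group and meta to a methyl group, as a place where a small change can remove most of the maximal response. Nothing measured here explains the drop. As far as these compounds go, it remains open whether hydroxyl or fluorine at this same carbon would lower the response as amino does. From the compounds shown here alone, it also remains open whether a larger amine, such as dimethylamino, would lower it further.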